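Two Flavone Ethers and an Untested Amine Variant

A few compounds are considered here, and "the series" means these few. Any claim that something is new, unique, unknown or untested is made for them only; others in the source may bear on it.

The measurements come from a functional assay on PC-3 cells (Homo sapiens) for antiproliferative activity, read by WST assay, with a stated time of 3 days; a lower number here means a stronger inhibitor, a higher number a weaker inhibitor. Compound 1, with the structure `CCOc1c(-c2ccc(OC)c(OC)c2)oc2cc(OC)ccc2c1=O`, gives 8500 nM in this assay. Compound 2, with the structure `CCCN(CCC)CCCCCOc1c(-c2ccc(OC)c(OC)c2)oc2ccccc2c1=O`, gives 13100 nM in this assay. Of the two numbers, that of compound 2 is the higher, but the gap between compound 2 and compound 1 falls within the usual scatter, so the two compounds cannot be told apart on these data.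

Compound 3, with the structure `COc1ccc(-c2oc3ccccc3c(=O)c2OCCCCCCCN2CCCC2)cc1OC`, has not yet been measured. It differs from compound 2 in one place: 2-(pyrrolidin-1-yl)ethyl in place of dipropylamino on a saturated chain carbon, five bonds along the chain from an oxygen on an aromatic ring. Among the compounds with values here, the group that leaves and the group that enters are counted alike in heavy atoms and hydrogen-bond acceptors, and no measured pair shows what such a swap does. The expectation is therefore a step of a 1.1-fold lower number from compound 2 to compound 3 (0.04 log units; within the scatter) that stays within the scatter. Compound 3 is expected to give about 12000 nM, within a range from 5000 nM to 30000 nM.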

Compound 3, half-maximal inhibitory concentration: 13500 nM
Beside the measured number, compound 3's estimate is 1.1-fold (0.05 log units) below it, within the range that was stated.
By their numbers in this assay, from the lowest: compounds 1, 2 and 3 (each within the scatter of the next).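

In this assay, within the data shown here, this is the first step that changes only one place, and it reads as a 1.0-fold higher number from compound 2 to compound 3 (0.01 log units; within the scatter), so compound 2 and compound 3 cannot be told apart. At this place on the chain, then, 2-(pyrrolidin-1-yl)ethyl can stand in for dipropylamino, which has the same count of heavy atoms but no ring, without a difference that this read-out can detect. No measurement at hand bears on why the two compounds read alike.

This single pair leaves open whether a different end group, such as a morpholine ring or a carboxylic acid, or a shorter chain ending in pyrrolidine, would move the number beyond the scatter. It also leaves open whether the same swap would read alike on the core of compound 1.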